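This account rests on a few compounds, and the source may have more. Where it says the series, first, only, none or still open, it means among the compounds named here.

Three compounds of the series have been run in a functional assay on HaCaT cells (Homo sapiens) for cytotoxicity, read by ELISA and LDH release, with a stated time of 6 h, tested at 25 ug/mL; on this read-out higher numbers stand for a weaker effect at the one concentration tested and lower numbers for a stronger effect. Compound 1 `C=C1C(=O)O[C@H](C2=C(C)C(OC)CC2=O)[C@@H]1[C@@H](O)CC(C)=O` gives 5%. Compound 2 `C=C1C(=O)O[C@H](C2=C(C)C(O)CC2=O)[C@@H]1CCC(C)=O` gives 3%. Compound 3 `C=C1C(=O)O[C@H](C2=C(C)[C@@H](OC)CC2=O)[C@@H]1CCC(C)=O` gives 7%, the highest of the three numbers, though its gaps to compound 1 and to compound 2 both lie within the scatter, so the three read alike. Compound 4 `C=C1C(=O)O[C@H](C2=C(C)[C@@H](O)CC2=O)[C@@H]1CCC(C)=O` has not yet been measured. Compound 4 differs from compound 3 by hydrogen in place of methyl on an oxygen on a saturated carbon. For the measured compounds named here, no measured pair isolates this change. Compound 2, also a hydroxy compound, gives 3%, so no shift beyond the scatter is expected. The step is estimated at a number 3 percentage points lower from compound 3 to compound 4 (within the scatter). Compound 4 is expected at 4%, within 0% to 12%.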

Compound 4, a percentage reported as activity, at one concentration (the size of the read-out at that concentration, not a potency): 11%
Compound 4: middle estimate off by 7 percentage points, on the low side, and the stated range covers the measured number.
By their numbers in this assay, from the lowest: compounds 2, 1, 3 and 4 (each within the scatter of the next).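

In this assay, the methoxy to hydroxy change on this saturated carbon now has a direct reading, a number 4 percentage points higher from compound 3 to compound 4 (within the scatter), so hydrogen in place of methyl on this oxygen shows no effect that can be told from the scatter. The drawn configuration at this carbon also gives a number 8 percentage points higher from compound 2 to compound 4 (within the scatter). That step compares a defined stereocentre with an undefined one, not two defined configurations: the fact that one of compounds 2 and 4 is drawn with a defined configuration and the other without, at the place where they differ

From the compounds shown here alone, whether the opposite configuration would read apart from compound 4 stays open. So does whether an ethoxy group, an acetoxy group or an amine on this carbon would read apart from methoxy and hydroxy.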